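Thiazole to Pyridine: What Clearance to Expect

The source may hold more compounds than are shown below. What is called first, only, known or untested is meant among the compounds shown, and "the series" means these compounds.

Measured so far in an ADME assay on microsomes from liver (Homo sapiens) for metabolic stability; on this read-out higher numbers stand for fast clearance and lower numbers for slow clearance:
compound 1, `O=c1n(Cc2nc(-c3nccs3)cn2CCCCO)c2cnccc2n1C1CC1`, gives < 8 mL.min-1.g-1; this result is a limit of the assay, not a number.
compound 2, `COC(=O)c1nc(Cn2c(=O)n(C3CC3)c3ccncc32)n(CCCCO)c1C`, gives 9 mL.min-1.g-1.

Compound 1 stands at the edge of what this assay reports: its result is only a limit, (the limit of < 8 mL.min-1.g-1 in this assay, at which 1 of the 2 values shown sits), so its true clearance is not pinned down beyond that. Going by the values given here, no step between two measured compounds that differ in one place is available, and compound 2 is not such a neighbour of compound 1, so its value serves only as context. Compound 3, `O=c1n(Cc2nc(-c3ccccn3)cn2CCCCO)c2cnccc2n1C1CC1`, differs from compound 1 by a single change, (pyridin-2-yl in place of 1,3-thiazol-2-yl on an aromatic carbon), that is, pyridin-2-yl in place of 1,3-thiazol-2-yl on an aromatic carbon. Among the compounds with values here, with no measured step to lean on, the expected step from compound 1 to compound 3 in this assay is a step that the limit leaves unreadable from compound 1 to compound 3, nothing beyond the usual scatter. Compound 3 is therefore estimated at 7 mL.min-1.g-1, with a range from 3.5 mL.min-1.g-1 to 14 mL.min-1.g-1.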

Compound 3, intrinsic clearance in microsomes: < 8 mL.min-1.g-1
Compound 3 was reported as a limit (the forecaster's own chance of this, stated with the estimate: 55%); the middle value does not contradict the limit.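

In this assay compound 1 and compound 3 both rest on a limit of the assay, so no step can be read for pyridin-2-yl in place of 1,3-thiazol-2-yl: the limit of < 8 mL.min-1.g-1 in this assay, at which 2 of the 3 values shown sit. The compounds shown leave open how low the true clearance of either compound lies and whether the two differ at all.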